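A few compounds are considered here, and "the series" means these few. Any claim that something is new, unique, unknown or untested is made for them only; others in the source may bear on it.

Measured compounds:
compound 1, `O=S(=O)(NCCCCNCc1ccc(Br)cc1)c1cc(C(F)(F)F)cc(C(F)(F)F)c1`, 2200 nM
compound 2, `O=S(=O)(NCCCNCc1ccc(Cl)cc1)c1cc(C(F)(F)F)cc(C(F)(F)F)c1`, 2900 nM
compound 3, `COc1cccc(CNCCCNS(=O)(=O)c2cc(C(F)(F)F)cc(C(F)(F)F)c2)c1`, 4500 nM

All three share one core and differ only in the benzyl group on the amine nitrogen. In a functional assay on BE(2)-C cells (Homo sapiens) for inhibition, read by MTT assay, with a stated time of 72 h (on this read-out higher numbers stand for weaker inhibition of growth and lower numbers for stronger inhibition of growth), compound 3 gives the highest of the three numbers; the gap a 2.0-fold higher number from compound 1 to compound 3 (0.31 log units; beyond the scatter) is modest, while a 1.6-fold higher number from compound 2 to compound 3 (0.19 log units; within the scatter) stays within the scatter. Compound 4, `O=S(=O)(NCCCNCc1ccccc1Cl)c1cc(C(F)(F)F)cc(C(F)(F)F)c1`, is not yet measured. It differs from compound 3 by 2-chlorophenyl in place of 3-methoxyphenyl on a saturated chain carbon bound to an amine nitrogen. The nearest guide is the halogenated pair: the step of a 1.6-fold higher number from compound 2 to compound 3 (0.19 log units; within the scatter) suggests that going back from methoxy to a chlorine-bearing benzyl group, now at the 2-position, should bring only a small change, if any, beyond the scatter. Compound 4 is therefore expected to give 3000 nM, somewhere between 1500 nM and 6000 nM, an estimated step of a 1.5-fold lower number from compound 3 to compound 4 (0.18 log units; within the scatter).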

Compound 4, concentration for 50% growth inhibition: 15000 nM
For compound 4 the middle estimate is 5.0-fold (0.70 log units) below the measured one, and the stated range ends below it.
By their numbers in this assay, from the lowest: compounds 1, 2 and 3 (each within the scatter of the next, the first and the last beyond it); then compound 4.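

The position of the chlorine on the benzyl group matters: 2-chlorophenyl in place of 4-chlorophenyl gives a 5.2-fold higher number from compound 2 to compound 4 (0.71 log units; beyond the scatter), although both groups carry the same halogen. The other steps, a 3.3-fold higher number from compound 3 to compound 4 (0.52 log units; beyond the scatter) and a 6.8-fold higher number from compound 1 to compound 4 (0.83 log units; beyond the scatter), point the same way and set compound 4 apart as the weakest of the four growth inhibitors. Nothing shown here explains this loss.

As far as these compounds go, it remains open whether a 3-chlorophenyl group would behave like either chlorinated neighbour. A 2-methoxyphenyl or 2-fluorophenyl group could show whether the loss extends beyond 2-chlorophenyl.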